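The compounds below may be only part of what the source reports. "The series", "measured", "known", "first", "only" and "open" are said of these compounds alone.

Measured compounds:
compound 1 `CCCCCCCCCCCCCCCC(=O)O[C@H]1C(=O)OCC1(C)C`: 19600 nM
compound 2 `CC1(C)COC(=O)[C@@H]1OC(=O)c1ccccc1`: 23000 nM

Both compounds share the same core and differ only in the ester group attached to it. In an assay on isolated protein for inhibition of fatty acid synthase (Mus musculus), read by spectrophotometry, using NADPH, with stated times of 30 min and 3 min, in the presence of a further agent that is not named here (a lower number here means a stronger inhibitor, a higher number a weaker inhibitor), compound 1 gives 19600 nM, and compound 2 gives 23000 nM. Compound 2 has the highest of the two numbers, but its gap to compound 1 lies within the scatter of repeated measurements, so the two cannot be told apart on these data.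

Compound 3 `CC1(C)COC(=O)[C@@H]1OC(=O)c1ccc(C#N)cc1` is the next step from compound 2. The change is cyano in place of hydrogen on an aromatic carbon. For the measured compounds named here, no pair of measured compounds shows what such a change does here, so there is nothing to lean on beyond the two numbers above. The step is expected to be small, in no clear direction, and within the scatter: a 1.3-fold lower number from compound 2 to compound 3 (0.11 log units; within the scatter). Compound 3 is therefore estimated at 18000 nM in this assay, with a range from 7000 nM to 50000 nM.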

Compound 3, half-maximal inhibitory concentration: 21500 nM
Compound 3: the middle estimate sits 1.2-fold (0.08 log units) below what was measured, and the stated range covers the measured number.
By their numbers in this assay, from the lowest: compounds 1, 3 and 2 (each within the scatter of the next).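

For the compounds shown here, on the six-membered aromatic ring of carbon only, para to a large group, cyano in place of hydrogen gives a 1.1-fold lower number from compound 2 to compound 3 (0.03 log units; within the scatter) in this assay, and this is the first change at this position that can be read directly. The position therefore accepts this one group, a linear unit with a triple bond, with no difference that can be told from the scatter of repeated measurements. Nothing measured here bears on why the step is this small.

As far as these compounds go, whether other groups at this position, such as an amine, a carboxylic acid or a methoxy group, behave the same way stays open, since a single group cannot show a trend. Also open is whether any group placed here can bring the number clearly below those of the compounds shown.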